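Compound 3: methoxy in place of dimethylamino

The source may report more compounds than this note shows. Statements on the series, on what has been measured and on what is new or still open speak of the compounds shown alone.

In a functional assay on MT4 cells (Homo sapiens) for inhibition (a lower number here means a stronger inhibitor, a higher number a weaker inhibitor), compound 1 `C=C1[C@@H](O)[C@H](n2cnc3c(N)nc(N)nc32)O[C@@H]1CO` gives > 200000 nM, which is a limit and not a number. Compound 2 `C=C1[C@@H](O)[C@H](n2cnc3c(N(C)C)nc(N)nc32)O[C@@H]1CO` gives > 500000 nM, also a limit, so compound 2 has no measured number to stand on. Compound 3 `C=C1[C@@H](O)[C@H](n2cnc3c(OC)nc(N)nc32)O[C@@H]1CO` carries methoxy in place of the dimethylamino group of compound 2, on the same aromatic carbon: methoxy in place of dimethylamino on an aromatic carbon. For the measured compounds named here, the one measured step that bears on this carbon is a step that the two limits leave unreadable from compound 1 to compound 2, and it supplies no size to carry over. No direction can be read from it, so no step beyond the scatter is expected. The estimated step is a number no higher from compound 2 to compound 3 (the limit leaves the size open). For compound 3 the estimate is 500000 nM, with an expected range of 200000 nM to 1000000 nM, and a limit rather than a number is the likely report.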

Compound 3, half-maximal inhibitory concentration: > 500000 nM
Compound 3 gave a limit, no number; the forecaster's own chance of this, stated with the estimate: 85%; the middle value lies on the limit itself.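

In this assay, for the compounds shown here, compound 1, compound 2 and compound 3 all give limits and not numbers, so no step among them can be read. The compounds shown leave open whether any group on this aromatic carbon gives measurable inhibition, and how amino, dimethylamino and methoxy compare.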